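Replacing thiophen-2-yl on the carbonyl of compound 2

The source may hold more compounds than are shown below. What is called first, only, known or untested is meant among the compounds shown, and "the series" means these compounds.

Going by the values given here, in a functional assay on A2780 cells (Homo sapiens) for antiproliferative activity, read by fluorescence, with a stated time of 72 h (on this read-out higher numbers stand for weaker inhibition and lower numbers for stronger inhibition), compound 1 (`CN1CCC(C(=O)N2Cc3c(NC(=O)c4ccc5ccccc5c4)n[nH]c3C2(C)C)CC1`) gives 270 nM, and compound 2 (`CN1CCC(C(=O)N2Cc3c(NC(=O)c4cccs4)n[nH]c3C2(C)C)CC1`) gives 30 nM, the lower of the two numbers so far. The next compound, compound 3 (`CN1CCC(C(=O)N2Cc3c(NC(=O)Nc4cccc(F)c4)n[nH]c3C2(C)C)CC1`), keeps the shared core and changes one group: (3-fluorophenyl)amino in place of thiophen-2-yl on a carbonyl carbon. In words, it carries (3-fluorophenyl)amino in place of thiophen-2-yl on a carbonyl carbon.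

Among the compounds with values here, only one measured step bears on this place. It is a 9.0-fold lower number from compound 1 to compound 2 (0.95 log units; beyond the scatter), a move beyond the scatter that came with thiophen-2-yl replacing naphthalen-2-yl on the same carbonyl carbon. That step shows that this assay responds to changes here, and the thiophene compound sits at the favourable end. Within the data shown here, no measured compound yet carries the entering group, so the direction is only tentative. A moderate rise in the number is expected, smaller than the step already seen. The expected change is a 3.0-fold higher number from compound 2 to compound 3 (0.48 log units; beyond the scatter). Compound 3 is estimated at 90 nM, with an expected range from 20 nM to 400 nM.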

Compound 3, half-maximal inhibitory concentration: 350 nM
Compound 3: middle estimate off by 3.9-fold (0.59 log units), on the low side; low and high end bracket the measured number.
By their numbers in this assay, from the lowest: compound 2; then compounds 1 and 3 (each within the scatter of the next).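

In this assay, the position proves to be sensitive to more than the aryl group alone: exchanging (thiophen-2-yl)carbonyl for (3-fluorophenyl)carbamoyl gives a 12-fold higher number from compound 2 to compound 3 (1.07 log units; beyond the scatter) as a large step beyond the scatter. The other comparison, a 1.3-fold higher number from compound 1 to compound 3 (0.11 log units; within the scatter) within the scatter, does not separate these two compounds, so the (3-fluorophenyl)amino and naphthalen-2-yl groups give equivalent readings on this carbonyl carbon, and among the three compounds only compound 2 stands apart, with steps beyond the scatter to both of the others. No measurement is available here that would explain the difference in antiproliferative readings.

Compound 3 differs from compound 2 in both the ring and the amino nitrogen on the carbonyl carbon, so the compounds shown do not assign the step to either the entering hydrogen-bond donor, the six-membered ring or the fluorine. Going by these compounds, an unsubstituted phenylamino group, a thiophen-2-ylamino group and a 3-fluorophenyl group bonded directly to the carbonyl carbon would each separate these parts of the change, and whether any of them would match compound 2 remains open.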